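The compounds below may be only part of what the source reports. "The series", "measured", "known", "first", "only" and "open" are said of these compounds alone.

Compound 3 `CC1CCC(C(=O)N2CCc3nc(C#Cc4ccccc4)sc3C2)CC1` stands second highest among the three numbers in an assay on HEK293 cells for positive allosteric modulation of metabotropic glutamate receptor 5 (Homo sapiens), read by FLIPR, with a stated time of 1 h; a lower number here means that less compound is needed, a higher number that more compound is needed for the effect; in this assay compound 3 gives 190 nM. Compound 1 `O=C(C1CC(F)C1)N1CCc2nc(C#Cc3ccccc3)sc2C1` gives 85 nM, and compound 2 `COC1CC(C(=O)N2CCc3nc(C#Cc4ccccc4)sc3C2)C1` gives 640 nM. Compound 4 `O=C(c1cccc(Cl)c1)N1CCc2nc(C#Cc3ccccc3)sc2C1` differs from compound 3 by 3-chlorophenyl in place of 4-methylcyclohexyl on a carbonyl carbon. The measured steps that bear on it are those altering the group on the carbonyl carbon: a 2.2-fold higher number from compound 1 to compound 3 (0.35 log units; beyond the scatter) and a 3.4-fold lower number from compound 2 to compound 3 (0.53 log units; beyond the scatter), both modest. Within the data shown here, no measured step exchanges a saturated ring for an aromatic one, so the direction is open, and a step within or only modestly beyond the scatter is expected: a 1.3-fold lower number from compound 3 to compound 4 (0.10 log units; within the scatter). Compound 4 is therefore estimated at 150 nM, with a range from 40 nM to 600 nM.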

Compound 4, half-maximal effective concentration: 8.7 nM
Compound 4: middle estimate off by 17-fold (1.24 log units), on the high side; measured number below the stated range.
By their numbers in this assay, from the lowest: compound 4; then compound 1; then compound 3; then compound 2.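

The group on the carbonyl carbon turns out to matter far more than the saturated rings suggested: with 3-chlorophenyl there are a 22-fold lower number from compound 3 to compound 4 (1.34 log units; beyond the scatter), a 9.8-fold lower number from compound 1 to compound 4 (0.99 log units; beyond the scatter) and a 74-fold lower number from compound 2 to compound 4 (1.87 log units; beyond the scatter), so compound 4 stands clear of all three saturated-ring compounds. The 4-methylcyclohexyl and 3-chlorophenyl groups have the same heavy-atom count and no hydrogen-bond donors or acceptors, yet the step from one to the other is large. No measurement available here accounts for this step.

The compounds shown leave open whether the aromatic ring or the chlorine carries the step. From the compounds shown here alone, how a plain phenyl or a pyridyl ring would compare also stays open.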